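The source may hold more compounds than are shown below. What is called first, only, known or untested is meant among the compounds shown, and "the series" means these compounds.

Compounds and values so far:
- compound 1 `COc1cccc(Br)c1-c1nc(CN2CCC(C(=O)NCCCN3C[C@H](C)C[C@H](C)C3)CC2)c(C)o1`: 14900 nM
- compound 2 `COc1cccc(Cl)c1-c1nc(CN2CCC(C(=O)NCCCN3C[C@H](C)C[C@H](C)C3)CC2)c(C)o1`: 15800 nM
- compound 3 `Cc1cccc(C)c1-c1nc(CN2CCC(C(=O)NCCCN3C[C@H](C)C[C@H](C)C3)CC2)c(C)o1`: 21000 nM

All three were measured in an ADME assay on Huh7.5.1 cells (Homo sapiens) for cytotoxicity, read by ATP content, with a stated time of 48 h (on this read-out lower numbers stand for higher toxicity in this test and higher numbers for lower toxicity in this test), and they lie within the scatter of one another. Compound 3, at 21000 nM, is not separated from either of the other two.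

The next compound is compound 4 `Cc1ccc(-c2nc(CN3CCC(C(=O)NCCCN4C[C@H](C)C[C@H](C)C4)CC3)c(C)o2)cc1C`. It has the same atoms as compound 3, joined differently, with 3,4-dimethylphenyl in place of 2,6-dimethylphenyl on an aromatic carbon of the five-membered aromatic ring: 3,4-dimethylphenyl in place of 2,6-dimethylphenyl on an aromatic carbon.

Within the data shown here, three measured steps bear on this change. The exchange of halogen gave a 1.1-fold higher number from compound 1 to compound 2 (0.03 log units; within the scatter). The two exchanges that lead to 2,6-dimethylphenyl gave a 1.4-fold higher number from compound 1 to compound 3 (0.15 log units; within the scatter) and a 1.3-fold higher number from compound 2 to compound 3 (0.12 log units; within the scatter). Each of these stays within the scatter, so the aryl group has so far left this assay flat across compound 1, compound 2 and compound 3. However, no measured compound carries 3,4-dimethylphenyl, so these steps are only indirect evidence, and the range has to stay wide.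

No step beyond the scatter is expected, and no firm direction. The expected size is a 1.2-fold lower number from compound 3 to compound 4 (0.07 log units; within the scatter).

The estimate for compound 4 is 18000 nM, with an expected range of 9000 nM to 35000 nM.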

Compound 4, half-maximal cytotoxic concentration: 6910 nM
The estimate for compound 4 lay 2.6-fold (0.42 log units) above the measured number, and the stated range ends above it.
By their numbers in this assay, from the lowest: compound 4; then compounds 1, 2 and 3 (each within the scatter of the next).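

In this assay, among these compounds, 3,4-dimethylphenyl in place of 2,6-dimethylphenyl gives a 3.0-fold lower number from compound 3 to compound 4 (0.48 log units; beyond the scatter) and is the first change to pass the scatter, although the heavy-atom count, the hydrogen-bond donor and acceptor counts and the net charge of the group all stay the same. The same group also separates from the two methoxy-bearing aryl groups, with a 2.3-fold lower number from compound 2 to compound 4 (0.36 log units; beyond the scatter) and with a 2.2-fold lower number from compound 1 to compound 4 (0.33 log units; beyond the scatter), so the aryl group on this aromatic carbon of the five-membered ring does shift the number by a modest amount, even though compound 1, compound 2 and compound 3 showed no such separation. Nothing at hand accounts for the step.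

The compounds shown leave open whether plain phenyl or a single methyl group on the aryl ring would give a number nearer to compound 3 or to compound 4, and whether 3,4-dichlorophenyl or 3,4-dimethoxyphenyl would follow 3,4-dimethylphenyl. They also leave open whether the step would persist with a shorter chain in place of the chain that carries the terminal amine.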